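Replacing the Methoxyphenyl with a Fluorophenyl on the Sulfonate Oxygen

The compounds below may be only part of what the source reports. "The series", "measured", "known", "first", "only" and "open" are said of these compounds alone.

Compound 1 `COc1ccccc1OS(=O)(=O)c1ccc(N2CCN(C)C2=O)cc1`: 26000 nM
Compound 2 `CN1CCN(c2ccc(S(=O)(=O)Oc3cc(Cl)c(Cl)cc3Cl)cc2)C1=O`: 600 nM
Compound 3 `COc1ccc(OS(=O)(=O)c2ccc(N3CCN(C)C3=O)cc2)cc1`: a limit, > 100000 nM

In a functional assay on HT-29 cells (Homo sapiens) for antiproliferative activity, read by sulforhodamine B assay, with a stated time of 48 h (on this read-out higher numbers stand for weaker inhibition and lower numbers for stronger inhibition), compound 1 holds the highest of the two real numbers, with compound 2 sitting far lower. Compound 3 reaches only the assay limit (the limit of > 100000 nM in this assay, at which 1 of the 3 values shown sits). Compound 4 `CN1CCN(c2ccc(S(=O)(=O)Oc3ccc(F)cc3)cc2)C1=O` differs from compound 1 in one place: 4-fluorophenyl in place of 2-methoxyphenyl on an oxygen. Within the data shown here, the one measured step that touches this change is an at least 3.8-fold higher number from compound 1 to compound 3 (0.58 log units; beyond the scatter), where moving the group to the 4-position weakened inhibition. A similar, modest weakening or no step beyond the scatter is therefore expected here. Compound 4 is estimated at 35000 nM, within 9000 nM to 100000 nM, which means an expected 1.3-fold higher number from compound 1 to compound 4 (0.13 log units; within the scatter).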

Compound 4, half-maximal inhibitory concentration: > 100000 nM
Compound 4: a limit, no number (the forecaster's own chance of this, stated with the estimate: 30%); at least 2.8-fold (0.45 log units) between middle value and limit.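

Putting 4-fluorophenyl on the sulfonate oxygen gives an at least 3.8-fold higher number from compound 1 to compound 4 (0.58 log units; beyond the scatter), so 4-methoxyphenyl in compound 3 is no longer the only replacement for 2-methoxyphenyl that loses inhibition in this assay. Compound 4 gives a limit and not a number, and it joins compound 3 there: the limit of > 100000 nM in this assay, at which 2 of the 4 values shown sit. The step between these two compounds cannot be read.

The compounds shown leave open whether 2-fluorophenyl on this oxygen would hold inhibition as 2-methoxyphenyl does. They also leave open how a phenyl carrying an amine or a carboxylic acid would read here.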